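This account rests on a few compounds, and the source may have more. Where it says the series, first, only, none or still open, it means among the compounds named here.

Measured so far in a functional assay on HepG2 cells (Homo sapiens) for antiproliferative activity, read by MTT assay, with a stated time of 72 h; on this read-out lower numbers stand for stronger inhibition and higher numbers for weaker inhibition:
compound 1 `CC(C)(C)c1cn(C[C@H](O)[C@H]2OC(=O)C(OCc3ccccc3)=C2OCc2ccccc2)nn1` gives 29200 nM
compound 2 `O=C1O[C@H]([C@@H](O)Cn2cc(CCO)nn2)C(OCc2ccccc2)=C1OCc1ccccc1` gives 68100 nM
compound 3 `O=C1O[C@H]([C@@H](O)Cn2cc(C3CC3)nn2)C(OCc2ccccc2)=C1OCc1ccccc1` gives 38100 nM

Compound 3 sits within the scatter of both others: a 1.3-fold higher number from compound 1 to compound 3 (0.12 log units; within the scatter) and a 1.8-fold lower number from compound 2 to compound 3 (0.25 log units; within the scatter). Among the measured compounds shown here, the only step past the scatter is a 2.3-fold higher number from compound 1 to compound 2 (0.37 log units; beyond the scatter). Compound 4 `O=C1O[C@H]([C@@H](O)Cn2cc(CNS(=O)(=O)c3ccc(Cl)cc3)nn2)C(OCc2ccccc2)=C1OCc1ccccc1` differs from compound 3 by (((4-chlorophenyl)sulfonyl)amino)methyl in place of cyclopropyl on an aromatic carbon. For the measured compounds named here, all three measured steps vary the same ring position, so they bear on this one, but none brings in a group of this size, and the one step beyond the scatter, a 2.3-fold higher number from compound 1 to compound 2 (0.37 log units; beyond the scatter), was modest. No direction is well founded, and the step expected is a 1.1-fold lower number from compound 3 to compound 4 (0.04 log units; within the scatter), with a wide range. Compound 4 is estimated at 35000 nM, between 9000 nM and 120000 nM.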

Compound 4, half-maximal inhibitory concentration: 7510 nM
Estimate against measurement, compound 4: 4.7-fold (0.67 log units) above; the measured number lies below the stated range.
By their numbers in this assay, from the lowest: compound 4; then compounds 1, 3 and 2 (each within the scatter of the next, the first and the last beyond it).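

This position on the five-membered aromatic ring responds clearly in this assay to (((4-chlorophenyl)sulfonyl)amino)methyl: a 5.1-fold lower number from compound 3 to compound 4 (0.71 log units; beyond the scatter), a 3.9-fold lower number from compound 1 to compound 4 (0.59 log units; beyond the scatter) and a 9.1-fold lower number from compound 2 to compound 4 (0.96 log units; beyond the scatter). A group of 12 heavy atoms is therefore accepted here in place of the 3 of cyclopropyl, and the number falls rather than rises. No evidence at hand explains this step.

Which part of the group carries the step stays open: the sulfonyl, the amino hydrogen or the chlorine. A plain phenyl in place of 4-chlorophenyl, or a carboxamide in place of the sulfonyl, would bear on this.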